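Bromo-to-methyl swap on the aryl ring of compound 2

This account rests on a few compounds, and the source may have more. Where it says the series, first, only, none or still open, it means among the compounds named here.

Measured compounds:
- compound 1 `Cc1nn(C)c2c1C(c1cccc(Br)c1)=NCCN2`: 0.63 mg/kg
- compound 2 `CCc1nn(C)c2c1C(c1cccc(Br)c1)=NCCN2`: 1.25 mg/kg
- compound 3 `Cc1nn(C)c2c1C(c1cccc(F)c1)=NCCN2CCCN(C)C`: > 10 mg/kg

Among the measured compounds shown here, in a functional assay on the whole organism for positive allosteric modulation, with Rattus norvegicus as the target (on this read-out lower numbers stand for an effect already at smaller amounts and higher numbers for an effect only at larger amounts of compound), compound 1 gives 0.63 mg/kg and compound 2 gives 1.25 mg/kg; the step of a 2.0-fold higher number from compound 1 to compound 2 (0.30 log units; within the scatter) is the only single-point step measured. Compound 3 reaches only a limit of the assay in this assay, recorded as > 10 mg/kg (the limit of > 10 mg/kg in this assay, at which 1 of the 3 values shown sits), so it yields no number for comparison. Compound 2 therefore carries the highest number among the two actual values, with compound 1 as its nearest neighbour within the scatter.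

The compound to be measured is compound 4 `CCc1nn(C)c2c1C(c1cccc(C)c1)=NCCN2`, which differs from compound 2 by methyl in place of bromo on an aromatic carbon. For the measured compounds named here, no measured step touches the substituent on the six-membered aromatic ring: the one step known alters a saturated chain carbon on the shared core, and compound 3 differs from compound 2 in more than one place. The expectation for compound 4 therefore rests on compound 2 alone, with the step of a 2.0-fold higher number from compound 2 to compound 4 (0.30 log units; within the scatter) expected to fall within the scatter. Compound 4 is estimated at 2.5 mg/kg, between 0.8 mg/kg and 10 mg/kg.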

Compound 4, minimum effective dose: 5 mg/kg
Beside the measured number, compound 4's estimate is 2.0-fold (0.30 log units) below it; low and high end bracket the measured number.
By their numbers in this assay, from the lowest: compounds 1 and 2 (each within the scatter of the next); then compound 4. At a limit, above all of these: compound 3.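

Replacing bromo with methyl on this aromatic carbon gives, in this assay, a 4.0-fold higher number from compound 2 to compound 4 (0.60 log units; beyond the scatter), a modest step. Among the compounds shown here, the only earlier single-point step, a 2.0-fold higher number from compound 1 to compound 2 (0.30 log units; within the scatter), stayed within the scatter, so this is the first place where one change moves the read-out beyond it, and in this one pair the bromo compound gives the lower number. Nothing measured here gives a cause for this step.

The compounds shown leave open how a chloro, trifluoromethyl or methoxy group would read on this aromatic carbon, and whether the same swap reads alike on the core of compound 1. Compound 3 stands at a limit of the assay, > 10 mg/kg, so it gives no number for a fluoro group here.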